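The source may hold more compounds than are shown below. What is called first, only, known or untested is meant among the compounds shown, and "the series" means these compounds.

Compound 1, whose structure is `C/C(=C\COC(=O)NC(C)(C)C)C1=CC(=O)C(C)(C)O1`, is the starting point. In a functional assay on MT4 cells (Homo sapiens) for inhibition (a lower number here means a stronger inhibitor, a higher number a weaker inhibitor), compound 1 gives 2.1 ug/mL, the lowest of the three numbers measured here. Its closest companion is compound 2, `C/C(=C\COC(=O)NC(C)C)C1=CC(=O)C(C)(C)O1`, which in this assay gives 2.3 ug/mL; the step of a 1.1-fold higher number from compound 1 to compound 2 (0.04 log units; within the scatter) lies within the scatter, so the two cannot be ordered. The third measured compound, compound 3, `C/C(=C\C=C/C1CCCCC1)C1=CC(=O)C(C)(C)O1`, carries a different chain and in this assay gives 8.4 ug/mL, a number that stands beyond the scatter from that of compound 1.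

The new compound, compound 4, has the structure `C/C(=C\COC(=O)NC1CCCCC1)C1=CC(=O)C(C)(C)O1`. It differs from compound 1 in one place: cyclohexyl in place of tert-butyl on an amide-type nitrogen. Going by the values given here, the only measured step that bears on this change is the one from compound 1 to compound 2, where hydrogen replaced methyl at the same amide-type nitrogen substituent and the number moved by a 1.1-fold higher number from compound 1 to compound 2 (0.04 log units; within the scatter), well within the scatter. On that evidence a further change of the group on the amide-type nitrogen is not expected to shift this assay beyond the scatter in either direction. Compound 4 is therefore estimated to give 2.4 ug/mL in this assay, within a range from 1.1 ug/mL to 5 ug/mL. This estimate corresponds to an expected step of a 1.1-fold higher number from compound 1 to compound 4 (0.06 log units; within the scatter).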

Compound 4, half-maximal inhibitory concentration: 2.4 ug/mL
Beside the measured number, compound 4's estimate shows no gap at the digits printed; the range from low to high includes it.
By their numbers in this assay, from the lowest: compounds 1, 2 and 4 (each within the scatter of the next); then compound 3.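

Placing cyclohexyl where compound 1 carries tert-butyl on the amide-type nitrogen gives, in this assay, a 1.1-fold higher number from compound 1 to compound 4 (0.06 log units; within the scatter), and placing it where compound 2 carries isopropyl gives a 1.0-fold higher number from compound 2 to compound 4 (0.02 log units; within the scatter), so compounds 1, 2 and 4 cannot be ordered by their numbers. Until now, this nitrogen had carried only open-chain groups; compound 4 shows that a six-membered non-aromatic ring of carbon only, with more heavy atoms than tert-butyl, also gives a number within the scatter of those of compounds 1 and 2. Nothing given here accounts for this agreement among the three compounds.

All three groups on this nitrogen consist of carbon and hydrogen only, so the compounds shown leave open whether a phenyl or benzyl group, a longer chain such as n-octyl, or a chain ending in an amine or a carboxylic acid would stay within the scatter in this assay. They also leave open what happens if the amide hydrogen is replaced by a methyl group, since that hydrogen is present in compounds 1, 2 and 4.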